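The source may hold more compounds than are shown below. What is called first, only, known or untested is meant among the compounds shown, and "the series" means these compounds.

In a functional assay on a cell-free system (plasma) for inhibition of thromboxane A2 receptor (Homo sapiens) (on this read-out lower numbers stand for stronger inhibition and higher numbers for weaker inhibition), compound 1 `O=C(O)CCC/C=C\CC1C2CCC(O2)C1CSCCc1ccccc1` gives 5500 nM and stands alongside compound 2 `O=C(O)CCC/C=C\CC1C2CCC(O2)C1CSCCCc1ccccc1`, which gives 5000 nM; the step of a 1.1-fold lower number from compound 1 to compound 2 (0.04 log units; within the scatter) lies within the scatter. Compound 3 `CC/C=C/CCSCC1C2CCC(O2)C1C/C=C\CCCC(=O)O` differs from compound 1 by but-1-en-1-yl in place of phenyl on a saturated chain carbon, two bonds along the chain from a sulfur. For the measured compounds named here, only the step from compound 1 to compound 2 touches this part of the structure, and it was small. Going by the values given here, no measured compound lacks the aromatic ring, so nothing here shows what losing it does. A step of a 1.2-fold higher number from compound 1 to compound 3 (0.07 log units; within the scatter) is expected, hardly beyond the scatter. Compound 3 is estimated at 6500 nM, within a range from 2500 nM to 17000 nM.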

Compound 3, half-maximal inhibitory concentration: 700 nM
For compound 3 the middle estimate is 9.3-fold (0.97 log units) above the measured one; measured number below the stated range.
By their numbers in this assay, from the lowest: compound 3; then compounds 2 and 1 (each within the scatter of the next).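

Replacing the aromatic ring at this position with an open chain does change the result in this assay: but-1-en-1-yl in place of phenyl gives a 7.9-fold lower number from compound 1 to compound 3 (0.90 log units; beyond the scatter), and but-1-en-1-yl in place of benzyl gives a 7.1-fold lower number from compound 2 to compound 3 (0.85 log units; beyond the scatter). The earlier swap of phenyl for benzyl had stayed within the scatter, so this position is less indifferent than it first appeared, and an aromatic ring is not needed here. Nothing available explains why the open chain gives the lower number. The compounds shown do not separate the effect of the double bond from that of the open chain, as a saturated hexyl chain is not among them. Going by these compounds, how a shorter chain, or a chain ending in a hydroxyl or an amine, would read also stays open.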